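Propargyl to 4-cyanobenzyl on a ring amine nitrogen

The compounds below may be only part of what the source reports. "The series", "measured", "known", "first", "only" and "open" are said of these compounds alone.

Among the measured compounds shown here, compound 2 `C#CCN1CCN(CC(=O)N2CCN(c3ccc(C(=O)c4cc5ccc(N(CC)CC)cc5o4)cc3)CC2)CC1` stands alone as the one compound with a number in a functional assay on SGC-7901 cells (Homo sapiens) for cytotoxicity, read by MTT assay, with a stated time of 48 h; a higher number here means a weaker inhibitor, a lower number a stronger inhibitor: compound 2 gives 20100 nM. Compound 1 `CCN(CC)c1ccc2cc(C(=O)c3ccc(N4CCN(C(=O)CN5CCN(S(=O)(=O)c6ccc(F)cc6)CC5)CC4)cc3)oc2c1` differs from it only by carrying (4-fluorophenyl)sulfonyl instead of propargyl on an amine nitrogen in a ring. In this assay compound 1 gives only a limit, > 40000 nM. That value sits at the limit of > 40000 nM in this assay, at which 1 of the 2 values shown sits. For the measured compounds named here, the single measured step, an at least 1.9-fold lower number from compound 1 to compound 2 (0.29 log units; that floor lies within the scatter), is therefore a floor rather than a size, and it falls within the usual scatter.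

Compound 3 `CCN(CC)c1ccc2cc(C(=O)c3ccc(N4CCN(C(=O)CN5CCN(Cc6ccc(C#N)cc6)CC5)CC4)cc3)oc2c1` differs from compound 2 by 4-cyanophenyl in place of ethynyl on a saturated chain carbon bound to an amine nitrogen in a ring. Going by the values given here, only the step from compound 1 to compound 2 bears on this change, and it showed nothing beyond the scatter, so no step beyond the scatter is expected in this assay, with a fair chance of another limit. Compound 3 is estimated at 25000 nM, with a range from 8000 nM to 80000 nM. The expected step is a 1.2-fold higher number from compound 2 to compound 3 (0.09 log units; within the scatter).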

Compound 3, half-maximal inhibitory concentration: 26300 nM
Beside the measured number, compound 3's estimate is 1.1-fold (0.02 log units) below it; the range from low to high includes it.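

Among the compounds shown here, replacing ethynyl with 4-cyanophenyl on this saturated chain carbon adds a six-membered aromatic ring, yet the change gives a 1.3-fold higher number from compound 2 to compound 3 (0.12 log units; within the scatter), the first step at this position measured with a true number at both ends. In this assay, compound 1 gives only a limit and not a number: the limit of > 40000 nM in this assay, at which 1 of the 3 values shown sits. The other step available here, an at least 1.5-fold lower number from compound 1 to compound 3 (0.18 log units; that floor lies within the scatter), is therefore a floor rather than a size, so the sulfonyl compound cannot be ranked against either of the two compounds with numbers.

On these data alone, it remains open whether any group on this ring nitrogen can move the number beyond the scatter, such as a plain benzyl, an acetyl or a chain ending in a carboxylic acid. The compounds shown also leave open whether changes to the shared core would do so.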